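Amino for Methoxy on Two Related Cores

This account rests on a few compounds, and the source may have more. Where it says the series, first, only, none or still open, it means among the compounds named here.

Compound 1 `COc1ccc(-c2c[nH]c(=O)n2-c2cc(OC)c(OC)c(OC)c2)cc1OC` and compound 2 `COc1ccc(-c2c[nH]c(=O)n2-c2cc(OC)c(OC)c(OC)c2)cc1N` share one core and differ by amino in place of methoxy on an aromatic carbon. In a functional assay on A549 cells (Homo sapiens) for cytotoxicity, read by MTT assay, with a stated time of 48 h (a lower number here means a stronger inhibitor, a higher number a weaker inhibitor), compound 1 reaches only a limit of the assay, > 50000 nM. Compound 2 likewise returns a limit, > 50000 nM. The step that the two limits leave unreadable from compound 1 to compound 2 therefore cannot be sized, as the limit of > 50000 nM in this assay, at which 3 of the 3 values shown sit, shows. Compound 3 `COc1ccc(-c2cn(C(=O)Nc3cc(OC)c(OC)c(OC)c3)c(=O)n2-c2cc(OC)c(OC)c(OC)c2)cc1OC` carries a different core; how the two cores differ is not broken down here. In this assay compound 3 also gives a limit, > 50000 nM. Compound 4 `COc1ccc(-c2cn(C(=O)Nc3cc(OC)c(OC)c(OC)c3)c(=O)n2-c2cc(OC)c(OC)c(OC)c2)cc1N`, not yet measured, differs from compound 3 by amino in place of methoxy on an aromatic carbon, the same change made from compound 1 to compound 2. Given that compound 3 sits at the limit > 50000 nM, compound 4 is expected to give about 60000 nM, within 20000 nM to 200000 nM. The expected step is estimated as a step that the limit leaves unreadable from compound 3 to compound 4, essentially flat.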

Compound 4, half-maximal inhibitory concentration: 11100 nM
The estimate for compound 4 lay 5.4-fold (0.73 log units) above the measured number, and the stated range ends above it.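

In this assay, amino in place of methoxy, read one bond further out as 3,4-dimethoxyphenyl to 3-amino-4-methoxyphenyl, gives an at least 4.5-fold lower number from compound 3 to compound 4 (0.65 log units; beyond the scatter), so on the core of compound 3 the change brings a measurable value. The same change on the core of compound 1 cannot be read, so the series does not show whether the change acts alike on both cores: the limit of > 50000 nM in this assay, at which 3 of the 4 values shown sit. This leaves one readable pair, which shows the change working on one core and gives no measured size for carrying it from one core to the other.

The compounds shown leave open whether a hydroxyl, a methylamino or a dimethylamino group on that aromatic carbon would give a similar step. They also leave open whether an acetamide there would keep it.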